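Step from compound 3 to compound 4

The source may hold more compounds than are shown below. What is called first, only, known or untested is meant among the compounds shown, and "the series" means these compounds.

In an ADME assay on the whole organism for inhibition, with Oryza sativa as the target, with a stated time of 4 days (on this read-out lower numbers stand for stronger inhibition and higher numbers for weaker inhibition), compound 3 (`CCC(CC)Nc1nc(Cl)nc(N[C@@H](C)c2ccccc2)n1`) gives 35500 nM, the highest number of the three measured. Compound 1 (`CC[C@H](C)Nc1nc(Cl)nc(N[C@@H](C)c2ccccc2)n1`) gives 6920 nM, and compound 2 (`C[C@H](Nc1nc(Cl)nc(NC(C)(C)C)n1)c1ccccc1`) gives 3310 nM. Compound 4 (`CCN(c1nc(Cl)nc(N[C@@H](C)c2ccccc2)n1)C(C)C`) has not been measured in this assay. It has the same atoms as compound 3, joined differently: ethyl(isopropyl)amino in place of (pentan-3-yl)amino on an aromatic carbon.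

The three measured steps all change the group at this place and show that the number responds to it: a 2.1-fold lower number from compound 1 to compound 2 (0.32 log units; beyond the scatter), a 5.1-fold higher number from compound 1 to compound 3 (0.71 log units; beyond the scatter) and an 11-fold higher number from compound 2 to compound 3 (1.03 log units; beyond the scatter). These steps range from modest to large. None of them brings in a group such as ethyl(isopropyl)amino, so they indicate the possible size of the change but not its direction. A small move to a higher number is tentatively expected, with wide uncertainty. The expected step is a 1.7-fold higher number from compound 3 to compound 4 (0.23 log units; within the scatter). For compound 4 the estimated value is 60000 nM, with an expected range of 18000 nM to 200000 nM.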

Compound 4, half-maximal inhibitory concentration: 537 nM
Estimate against measurement, compound 4: 110-fold (2.05 log units) above, outside the stated range (below it).
By their numbers in this assay, from the lowest: compound 4; then compound 2; then compound 1; then compound 3.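

In this assay, rejoining the atoms of (pentan-3-yl)amino as ethyl(isopropyl)amino gives a 66-fold lower number from compound 3 to compound 4 (1.82 log units; beyond the scatter), so the number at this position depends on how the group is joined and not only on its heavy-atom count. The new group, with 0 hydrogen-bond donors against 1 for (pentan-3-yl)amino, also improves on the two other amino groups, with a 6.2-fold lower number from compound 2 to compound 4 (0.79 log units; beyond the scatter) and a 13-fold lower number from compound 1 to compound 4 (1.11 log units; beyond the scatter), which places compound 4 lowest of the four. Nothing available here accounts for the drop.

From the compounds shown here alone, with a single example of a nitrogen carrying two alkyl groups, it remains open whether the missing amino hydrogen or the particular ethyl and isopropyl pairing matters. Diethylamino or dimethylamino at this place would help separate those two readings.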